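Swapping a hydroxypropyl for a ureidomethyl at sulfur

The source may report more compounds than this note shows. Statements on the series, on what has been measured and on what is new or still open speak of the compounds shown alone.

Compound 1 `CC(O)CSc1nc(NCc2ccc(-c3ccccn3)cc2)c2[nH]nc(C(C)C)c2n1`: 62 nM
Compound 2 `CCC(O)CSc1nc(NCc2ccc(-c3ccccn3)cc2)c2[nH]nc(C(C)C)c2n1`: 273 nM
Compound 3 `CC(C)c1n[nH]c2c(NCc3ccc(-c4ccccn4)cc3)nc(SC[C@H](O)CN)nc12`: 63 nM

All three share one core and differ only in the group on the saturated chain carbon bound to a sulfur, tested in a functional assay on HT cells (Homo sapiens) for antiproliferative activity, read by fluorescence, with a stated time of 72 h; a higher number here means a weaker inhibitor of growth, a lower number a stronger inhibitor of growth. Compound 2 stands at the highest number of the three, with both neighbours at a clear distance: a 4.4-fold higher number from compound 1 to compound 2 (0.64 log units; beyond the scatter), and a 4.3-fold lower number from compound 2 to compound 3 (0.64 log units; beyond the scatter). Compound 1 and compound 3 lie within the scatter of each other, a 1.0-fold higher number from compound 1 to compound 3 (0.01 log units; within the scatter).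

Compound 4 `CC(C)c1n[nH]c2c(NCc3ccc(-c4ccccn4)cc3)nc(SCCNC(N)=O)nc12` has not yet been measured. Its change from compound 2 is ureidomethyl in place of 1-hydroxypropyl on a saturated chain carbon bound to a sulfur. Among the compounds with values here, two steps bear on it. Adding a methyl two bonds from the oxygen raised the number, and replacing the 1-hydroxypropyl with 2-amino-1-hydroxyethyl brought it back down. Compound 4 likewise gives up the 1-hydroxypropyl for a group carrying 2 hydrogen-bond donors, so a modest downward step is expected, a 3.0-fold lower number from compound 2 to compound 4 (0.48 log units; beyond the scatter). No ureidomethyl has been measured here, so the range is kept wide. For compound 4 the expected value is 90 nM, between 35 nM and 250 nM.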

Compound 4, concentration for 50% growth inhibition: 240 nM
The estimate for compound 4 lay 2.7-fold (0.43 log units) below the measured number; the range from low to high includes it.
By their numbers in this assay, from the lowest: compounds 1 and 3 (each within the scatter of the next); then compounds 4 and 2 (each within the scatter of the next).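

The ureidomethyl group does not repeat what 2-amino-1-hydroxyethyl did on the saturated chain carbon bound to a sulfur: a 1.1-fold lower number from compound 2 to compound 4 (0.06 log units; within the scatter) in this assay and so stands level with the 1-hydroxypropyl group. Set against the two better groups, the same change gives a 3.8-fold higher number from compound 3 to compound 4 (0.58 log units; beyond the scatter) and a 3.9-fold higher number from compound 1 to compound 4 (0.59 log units; beyond the scatter) at this position. Of the three replacements of 1-hydroxypropyl shown, ureidomethyl alone stays within the scatter of it, so this position distinguishes among them, and a count of hydrogen-bond donors does not predict the result.

No measurement shown explains why the groups differ. Still open, going by these compounds, is whether a plain amine without the hydroxyl would match compound 3, and how a carboxylic acid or a longer urea chain would fare at this position.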